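Thioether Variants Assessed for Cytotoxicity in MCF7 Cells

This account rests on a few compounds, and the source may have more. Where it says the series, first, only, none or still open, it means among the compounds named here.

Measured so far:
compound 1 `Cc1nnc(SCc2cc(=O)c3ccccc3o2)o1`: > 25000 nM
compound 2 `Cc1nnc(SCc2coc3ccc(Cl)cc3c2=O)s1`: 13400 nM
compound 3 `Cc1cc(C)nc(SCc2coc3ccccc3c2=O)n1`: > 25000 nM

All three were examined in a functional assay on MCF7 cells (Homo sapiens) for cytotoxicity, read by MTT assay, with a stated time of 72 h; a lower number here means a stronger inhibitor, a higher number a weaker inhibitor. Compound 1 reaches only the limit of the measurement, > 25000 nM, so no number is known for it. Compound 3 likewise stops at the limit of the measurement, > 25000 nM. Compound 2 is the only one of the three to give a number, 13400 nM, and even that is weak. Where compound 1 stands is told only by the limit of > 25000 nM in this assay, at which 2 of the 3 values shown sit; it cannot be ordered against compound 3, and it is at best a weak inhibitor in this assay.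

Compound 4 `Nc1nnc(SCc2cc(=O)c3ccccc3o2)s1` has not yet been measured. It differs from compound 1 in one place: 5-amino-1,3,4-thiadiazol-2-yl in place of 5-methyl-1,3,4-oxadiazol-2-yl on a sulfur. For the measured compounds named here, no step between measured compounds resembles this exchange, so the expectation rests on the weak values of all three measured compounds. The step of an at least 1.2-fold lower number from compound 1 to compound 4 (0.09 log units; that floor lies within the scatter) is expected to be small, and it is expected to lie within the usual scatter rather than beyond it. Compound 4 is therefore estimated at 20000 nM, with a range from 7000 nM to 60000 nM, and it may well again return only a limit in this assay.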

Compound 4, half-maximal inhibitory concentration: > 25000 nM
Compound 4 ended at the assay's limit (the forecaster's own chance of this, stated with the estimate: 55%); middle value at least 1.2-fold (0.09 log units) from the limit.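

In this assay, for the compounds shown here, compound 4 gives > 25000 nM, a limit and not a number, and since compound 1 also stands at a limit, no step between compound 1 and compound 4 can be read. The compounds shown leave open whether 5-amino-1,3,4-thiadiazol-2-yl in place of 5-methyl-1,3,4-oxadiazol-2-yl on a sulfur changes the result in this assay at all.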